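The compounds below may be only part of what the source reports. "The series", "measured", "known", "first", "only" and "open" are said of these compounds alone.

Compound 1 `COc1ccc(Cl)cc1-n1ncc(-c2nnc(-c3cccc(F)c3)o2)c1C`, compound 2 `COc1ccc(Cl)cc1-n1ncc(-c2nnc(-c3ccc(F)cc3)o2)c1C` and compound 3 `COc1ccc(Cl)cc1-n1ncc(-c2nnc(-c3ccccc3)o2)c1C` share a common core and differ only in the aromatic ring at its far end. In a physicochemical assay for lipophilicity, using the shake flask method, measured as octanol-water partition (a higher number here means a more lipophilic compound, a lower number a more polar compound), compound 1 gives 4.28, compound 2 gives 4.26, and compound 3 gives 4.32. The steps among them are small: a number 0.02 log units lower from compound 1 to compound 2 (within the scatter), a number 0.04 log units higher from compound 1 to compound 3 (within the scatter) and a number 0.06 log units higher from compound 2 to compound 3 (within the scatter). Compound 3 thus carries the highest of the three numbers, but its separation from compound 1 and from compound 2 lies within the scatter, so no order among the three can be read from these values.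

Compound 4 `COc1ccc(Cl)cc1-n1ncc(-c2nnc(-c3ccc(Br)cc3)o2)c1C` takes the next step from compound 3: bromo in place of hydrogen on an aromatic carbon. The measured steps that bear on it are those where a fluoro left and a hydrogen entered, from compound 1 and from compound 2 to compound 3, each within the scatter. Among the compounds with values here, the present change runs the other way and brings in a bromine instead of a fluorine, and no measured pair shows that exchange. On that basis compound 4 is expected to sit above compound 3 in this assay, with an estimated step of a number 0.58 log units higher from compound 3 to compound 4 (beyond the scatter). The estimate for compound 4 is 4.9, with a range from 4.5 to 5.3.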

Compound 4, partition coefficient: 4.88
The estimate for compound 4 lay 0.02 log units above the measured number; measured number inside the range.
By their numbers in this assay, from the lowest: compounds 2, 1 and 3 (each within the scatter of the next); then compound 4.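

In this assay the far aromatic ring, which had shown no readable difference among the earlier compounds, now gives a step that clears the scatter: bromo in place of hydrogen on an aromatic carbon, para to a large group, gives a number 0.56 log units higher from compound 3 to compound 4 (beyond the scatter) in this comparison. The same holds against the two fluoro compounds, since bromo in place of fluoro gives a number 0.62 log units higher from compound 2 to compound 4 (beyond the scatter) and 4-bromophenyl in place of 3-fluorophenyl gives a number 0.60 log units higher from compound 1 to compound 4 (beyond the scatter) on the same shared core. Where fluoro and hydrogen could not be told apart, this ring is thus shown to respond to the group it carries, and compound 4 stands clear of all three earlier compounds, whose own numbers remain within the scatter of one another. Nothing in the material shown accounts for why bromo separates from hydrogen and fluoro here while fluoro does not.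

What the compounds shown leave open is whether a chloro, a methyl or a trifluoromethyl in the same place would give a step of similar size. They also leave open whether an amine or a carboxylic acid there would move the number in the opposite direction.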